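A Methyl on the Oxygen, Three Limits, One Expectation

This account rests on a few compounds, and the source may have more. Where it says the series, first, only, none or still open, it means among the compounds named here.

Compound 1 `C[N+](C)(Cc1ccccc1)c1ccccc1O` and compound 3 `COc1ccccc1[N+](C)(C)Cc1ccccc1` differ by a single change, (methyl in place of hydrogen on an oxygen on an aromatic ring). In a functional assay with Cavia porcellus as the target (on this read-out lower numbers stand for stronger inhibition and higher numbers for weaker inhibition), compound 1 gives only a limit of the assay, > 3000 nM. In this assay compound 3 likewise gives only a limit, > 3000 nM. The step between them, a step that the two limits leave unreadable from compound 1 to compound 3, therefore cannot be read from these two values. Compound 2 `C[N+](C)(Cc1ccccc1)c1cccc(O)c1` has the same atoms as compound 1 joined differently; the difference between the two cores is not broken down here. In this assay compound 2 also gives only a limit, > 3000 nM. What the three measured values share is told by the limit of > 3000 nM in this assay, at which 3 of the 3 values shown sit. Among the compounds with values here, compound 4 `COc1cccc([N+](C)(C)Cc2ccccc2)c1` is not yet measured; it differs from compound 2 by methyl in place of hydrogen on an oxygen on an aromatic ring, the same change as the one from compound 1 to compound 3, at the same place. Because of the limit of > 3000 nM in this assay, at which 3 of the 3 values shown sit, the step from compound 2 to compound 4 in this assay is expected to be a step that the limit leaves unreadable from compound 2 to compound 4, unreadable like the earlier one. Compound 4 is therefore expected to give about 10000 nM, most likely again as a limit rather than a number, between 3000 nM and 60000 nM.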

Compound 4, half-maximal inhibitory concentration: > 3000 nM
Compound 4: no number, only a limit; the forecaster's own chance of this, stated with the estimate: 85%; the middle value does not contradict the limit.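

In this assay compound 4 gives > 3000 nM, which is a limit of the assay and not a number. The change from compound 2 to compound 4 therefore gives no readable step. The compounds shown leave open how strongly any of the four inhibits, and whether going from hydroxy to methoxy changes that at all, as all four share one result: the limit of > 3000 nM in this assay, at which 4 of the 4 values shown sit.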